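Moving the Furan Attachment in a Dihydropyrimidinone Series

The source may hold more compounds than are shown below. What is called first, only, known or untested is meant among the compounds shown, and "the series" means these compounds.

Measured compounds:
- Compound 1 `CCN(CC)C(=O)C1=C(C)NC(=O)NC1c1ccoc1`: 12%
- Compound 2 `CCSC(=O)C1=C(C)NC(=O)NC1c1ccoc1`: 1%
- Compound 3 `CCC(CC)OC(=O)C1=C(C)NC(=O)NC1c1ccco1`: 35%

These three compounds were tested in an assay on membranes from HEK293 cells for displacement of a labelled ligand from adenosine receptor A2b (Homo sapiens), read by scintillation counting, with a stated time of 30 min, tested at 1 uM; on this read-out higher numbers stand for more inhibition at the one concentration tested (going by the name of the read-out) and lower numbers for less inhibition. Compound 3 stands highest of the three; its nearest neighbour is compound 1, and compound 2 lies furthest below it, both gaps beyond the scatter.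

Among the measured compounds shown here, the only step between compounds that differ in a single place is a number 11 percentage points lower from compound 1 to compound 2 (beyond the scatter). That step concerns the group on a carbonyl carbon and says nothing about the furan ring, so it does not bear on the change considered here.

Compound 4 `CCC(CC)OC(=O)C1=C(C)NC(=O)NC1c1ccoc1` is the next compound. It differs from compound 3 in one place: furan-3-yl in place of furan-2-yl on a saturated ring carbon. Compounds 1 and 2 already carry furan-3-yl and give lower numbers than compound 3, but they also differ from compound 3 on the carbonyl carbon, so their values cannot be read as a measure of the furan change alone.

For the measured compounds named here, with no measured step addressing this change, the expected shift in this assay for compound 4 is small, a number 7 percentage points lower from compound 3 to compound 4 (within the scatter), and carries wide uncertainty. Compound 4 is therefore estimated at 28%, with a range from 5% to 50%.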

Compound 4, a percentage reported as inhibition, at one concentration (the size of the read-out at that concentration, not a potency): 28%
Compound 4: the middle estimate sits on the measured number at the digits printed; the range from low to high includes it.
By their numbers in this assay, from the lowest: compound 2; then compound 1; then compounds 4 and 3 (each within the scatter of the next).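

In this assay, among the compounds shown here, moving the attachment from furan-2-yl to furan-3-yl on the saturated ring carbon gives a number 7 percentage points lower from compound 3 to compound 4 (within the scatter) and so does not separate the two compounds, which makes this the first direct reading of the furan change, on a single pair that shares the (pentan-3-yl)oxy group. With furan-3-yl now held constant, the group on the carbonyl carbon can also be read on its own: (pentan-3-yl)oxy in place of ethylsulfanyl gives a number 27 percentage points higher from compound 2 to compound 4 (beyond the scatter) and (pentan-3-yl)oxy in place of diethylamino gives a number 16 percentage points higher from compound 1 to compound 4 (beyond the scatter), so among these compounds the carbonyl group shifts the number beyond the scatter while the furan attachment does not. Nothing available here explains why either change has the size it has.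

Going by these compounds, whether furan-2-yl and furan-3-yl would also stay within the scatter of each other alongside diethylamino or ethylsulfanyl remains open. Also open, on these data alone, is how a different ring on the saturated ring carbon, such as phenyl or thiophen-2-yl, or a longer alkoxy chain on the carbonyl carbon would read in this assay on this shared core.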